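The source may report more compounds than this note shows. Statements on the series, on what has been measured and on what is new or still open speak of the compounds shown alone.

Measured compounds in a functional assay on CHO cells for agonist activity at Free fatty acid receptor 1 (Homo sapiens), read by FLIPR and calcium flux; on this read-out higher numbers stand for an effect only at larger amounts of compound and lower numbers for an effect already at smaller amounts:
Compound 1, `Cc1cccc(C)c1-c1cccc(COc2ccc(S(=O)(=O)CC(=O)O)cc2)c1`, gives 66.1 nM.
Compound 2, `COc1cc(C)c(-c2cccc(COc3ccc(S(=O)(=O)C(C)C(=O)O)cc3)c2)c(C)c1`, reaches only a limit of the assay, > 1000 nM.
Compound 3, `Cc1nc(-c2ccccc2F)sc1COc1ccc(S(=O)(=O)CC(=O)O)cc1`, gives 550 nM.

Compound 3 stands at the higher of the two numbers reported in this assay. Its nearest neighbour is compound 1, whose number lies lower by a gap that is beyond the usual scatter of repeated measurements. Compound 2 sits at the limit of the assay the limit of > 1000 nM in this assay, at which 1 of the 3 values shown sits, and so contributes no number that could be placed in order with the others. For the measured compounds named here, no two of the measured compounds differ in only one place, so no measured step is available from which the weight of a single change could be read off.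

Compound 4, `Cc1nc(-c2cccc(Cl)c2)sc1COc1ccc(S(=O)(=O)CC(=O)O)cc1`, differs from compound 3 by 3-chlorophenyl in place of 2-fluorophenyl on an aromatic carbon. Going by the values given here, nothing among the measured compounds speaks to this particular exchange on the five-membered ring. Compound 4 is therefore expected to stay close to compound 3, with an expected step from compound 3 to compound 4 of a 1.4-fold lower number from compound 3 to compound 4 (0.14 log units; within the scatter), which is not beyond the scatter. For compound 4 the estimated value in this assay is 400 nM, with a range from 120 nM to 1500 nM.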

Compound 4, half-maximal effective concentration: 251 nM
Estimate against measurement, compound 4: 1.6-fold (0.20 log units) above; low and high end bracket the measured number.
By their numbers in this assay, from the lowest: compound 1; then compound 4; then compound 3. At a limit, above all of these: compound 2.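

In this assay, for the compounds shown here, the exchange of 2-fluorophenyl for 3-chlorophenyl on the aromatic carbon of the five-membered aromatic ring with 1 nitrogen and 1 sulfur gives a 2.2-fold lower number from compound 3 to compound 4 (0.34 log units; beyond the scatter) and is the first single change that can be read, showing that the number responds to the aryl group at this position. The two groups match in heavy-atom count and in hydrogen-bond donors and acceptors, so those counts do not separate them, whereas the halogen and its place on the phenyl ring both change in this one step. Nothing shown gives a reason for the step.

Going by these compounds, whether the step follows the chlorine or its place on the phenyl ring remains open, and a 3-fluorophenyl or 2-chlorophenyl group at this position would separate the two. On these data alone, how far this position tolerates a non-halogen group, such as an amine or a methoxy group, also remains open, and no step can be read between the other compounds, which each differ in more than one place.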